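This account rests on a few compounds, and the source may have more. Where it says the series, first, only, none or still open, it means among the compounds named here.

Measured in a physicochemical assay for solubility, in phosphate buffer; a lower number here means a less soluble compound, a higher number a more soluble compound:
- compound 1 `C[C@H]1CN([C@@H](C)CO)C(=O)c2cccc(NC(=O)c3ccncc3)c2O[C@H]1CN(C)Cc1ccc(Oc2ccccc2)cc1`: 93000 nM
- compound 2 `C[C@H]1CN([C@@H](C)CO)C(=O)c2cccc(NC(=O)c3ccncc3)c2O[C@@H]1CN(C)Cc1ccccc1`: 100000 nM
- compound 3 `C[C@@H]1CN([C@H](C)CO)C(=O)c2cccc(NC(=O)c3ccncc3)c2O[C@H]1CN(C)Cc1ccc(Oc2ccccc2)cc1`: 1000 nM

Not yet measured: compound 4 `C[C@H]1CN([C@@H](C)CO)C(=O)c2cccc(NC(=O)c3ccncc3)c2O[C@@H]1CN(C)Cc1ccc(Oc2ccccc2)cc1`.

Compound 3 is the lowest of the three, with compound 1 and compound 2 both far higher. The change to compound 4 is the two compounds have the same atoms and bonds and differ only in configuration as drawn: 3 of 3 stereo elements differ (all stereocentres are inverted: mirror images); a stereocentre at a saturated ring carbon is drawn R in compound 3 and S in compound 4; a stereocentre at a saturated chain carbon is drawn R in compound 3 and S in compound 4; a stereocentre at a saturated ring carbon is drawn R in compound 3 and S in compound 4; all stereocentres are inverted, so the two are mirror images.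

Going by the values given here, one measured step bears on this: a 93-fold lower number from compound 1 to compound 3 (1.97 log units; beyond the scatter). It is large and comes with the fact that compounds 1 and 3 differ only in the configuration as drawn. That step inverts only two of the three stereo elements and does not give a mirror image, so its size does not carry over directly. It shows only that configuration can go with a large shift in this assay.

No step beyond the scatter is expected, and any drift is expected to be upward, towards the two higher compounds. The expected change is a 1.5-fold higher number from compound 3 to compound 4 (0.18 log units; within the scatter). For compound 4 the estimated value is 1500 nM, with an expected range of 500 nM to 30000 nM.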

Compound 4, solubility: 1000 nM
Compound 4: middle estimate off by 1.5-fold (0.18 log units), on the high side, and the stated range covers the measured number.
By their numbers in this assay, from the lowest: compounds 3 and 4 (each within the scatter of the next); then compounds 1 and 2 (each within the scatter of the next).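

In this assay, inverting all stereocentres gives no change at the digits printed from compound 3 to compound 4 (within the scatter), so the low level of compound 3 is shared by its mirror image: the fact that compounds 3 and 4 differ only in the configuration as drawn. Inverting a single stereocentre at a saturated ring carbon gives a 93-fold lower number from compound 1 to compound 4 (1.97 log units; beyond the scatter), so a change at that one ring carbon is enough to separate high from low numbers among the phenoxy compounds: the fact that compounds 1 and 4 differ only in the configuration as drawn. Phenoxy in place of hydrogen on an aromatic carbon gives a 100-fold lower number from compound 2 to compound 4 (2.00 log units; beyond the scatter), yet the phenoxy group does not go with a low number in every configuration, as compound 1 also carries it and gives 93000 nM.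

From the compounds shown here alone, whether the phenoxy step depends on configuration remains open, as it can be read only in the configuration of compound 4. Also open, going by these compounds, is how a methoxy group or a carboxylic acid in place of hydrogen on that aromatic carbon would read in this assay.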